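The compounds below may be only part of what the source reports. "The series", "measured", "known", "first", "only" and "open" are said of these compounds alone.

Working notes on the series, read in a functional assay on SEM cells (Homo sapiens) for cytotoxicity, with a stated time of 72 h; a higher number here means that more compound is needed for the effect, a lower number that less compound is needed. Compound 1 `C=C[C@@](C)(/C=C/c1ccc(OS(=O)(=O)C(F)(F)F)cc1)CCC=C(C)C` gives > 36600 nM, which is a limit and not a number. Compound 2 `C=C[C@@](C)(/C=C/c1ccc(Nc2ccccc2)cc1)CCC=C(C)C` gives > 36600 nM, again a limit. Compound 3 `C=C[C@@](C)(/C=C/c1ccc(Nc2ccc(F)c(F)c2)cc1)CCC=C(C)C` gives > 36600 nM, also a limit. Within the data shown here, compound 3 therefore has no numeric standing, and the whole series so far rests on (the limit of > 36600 nM in this assay, at which 3 of the 3 values shown sit).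

Compound 4 `C=C[C@@](C)(/C=C/c1ccc(Nc2cc(F)cc(F)c2)cc1)CCC=C(C)C` differs from compound 3 in one place: 3,5-difluorophenyl in place of 3,4-difluorophenyl on a nitrogen on an aromatic ring. The two have the same atoms, joined differently.

The closest measured change is a step that the two limits leave unreadable from compound 2 to compound 3, the one that brought in the 3,4-difluorophenyl group. The other two measured changes, a step that the two limits leave unreadable from compound 1 to compound 2 and a step that the two limits leave unreadable from compound 1 to compound 3, replace the ((trifluoromethyl)sulfonyl)oxy group on an aromatic carbon. None of the three yields a size, so none supports a shift in either direction. The expectation is therefore no readable change, and the estimated step is a number no higher from compound 3 to compound 4 (the limit leaves the size open). For compound 4 the estimated value is 36600 nM, with an expected range from 15000 nM to 73000 nM, and another limit is the likeliest report.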

Compound 4, half-maximal effective concentration: > 36600 nM
Compound 4: no number, only a limit; the forecaster's own chance of this, stated with the estimate: 80%; the middle value lies on the limit itself.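

In this assay compound 4 gives > 36600 nM, which is a limit and not a number. Among these compounds, no step linking compound 4 to compound 1, compound 2 or compound 3 can be read. The compounds shown leave open how the four compare and whether any of them reaches a numeric value in this assay: the limit of > 36600 nM in this assay, at which 4 of the 4 values shown sit.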